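The source may hold more compounds than are shown below. What is called first, only, known or untested is meant among the compounds shown, and "the series" means these compounds.

Working notes on the series.

The series shares one core, carried by compound 1 `CCCCc1oc2ccc(/N=C/c3ccc(O)cc3)cc2c1C(=O)c1ccc(OC)cc1` and compound 2 `CCCCc1oc2ccc(/N=C/c3ccc(Cl)cc3Cl)cc2c1C(=O)c1ccc(OC)cc1`, and the compounds are compared in a functional assay, with a stated time of 30 min; a lower number here means a stronger inhibitor, a higher number a weaker inhibitor. In this assay compound 1 gives 22.8 ug/mL, while compound 2 gives 2.44 ug/mL. Among the compounds with values here, the one step measured so far, a 9.3-fold lower number from compound 1 to compound 2 (0.97 log units; beyond the scatter), is the only guide to how changes at this position play out. Within the data shown here, compound 2 therefore stands at the lower of the two numbers known, with compound 1 the nearest neighbour at a clearly higher value.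

Compound 3 `CCCCc1oc2ccc(/N=C/c3ccc(CC)cc3)cc2c1C(=O)c1ccc(OC)cc1` is the next member awaiting measurement. It differs from compound 2 in a single place: 4-ethylphenyl in place of 2,4-dichlorophenyl on a carbon with a double bond to nitrogen. Among the measured compounds shown here, no measured step covers this exact exchange, so the expectation rests on the fact that the one known change at this position, from compound 1 to compound 2, moved the number beyond the scatter. A group that is neither the hydroxyphenyl of compound 1 nor the dichlorophenyl of compound 2 is expected to land between them, closer to compound 2. The step is expected to be a 2.5-fold higher number from compound 2 to compound 3 (0.39 log units; beyond the scatter), a modest rise in this assay. Compound 3 is thus estimated at 6 ug/mL, with a range from 2 ug/mL to 18 ug/mL.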

Compound 3, half-maximal inhibitory concentration: 3.69 ug/mL
Compound 3: middle estimate off by 1.6-fold (0.21 log units), on the high side; low and high end bracket the measured number.
By their numbers in this assay, from the lowest: compounds 2 and 3 (each within the scatter of the next); then compound 1.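

In this assay the exchange of 2,4-dichlorophenyl for 4-ethylphenyl on the carbon with a double bond to nitrogen gives a 1.5-fold higher number from compound 2 to compound 3 (0.18 log units; within the scatter) and so does not separate the two groups, which shows that chlorine is not needed on this ring for a number in this range. Ethyl in place of hydroxy on an aromatic carbon gives a 6.2-fold lower number from compound 1 to compound 3 (0.79 log units; beyond the scatter) and so a single exchange on the ring is enough to move the number beyond the scatter, leaving the hydroxy-bearing member as the one of the three that stands apart from the other two. Nothing measured here accounts for either result.

Going by these compounds, it remains open whether other groups on this ring would follow the ethyl and dichloro examples or the hydroxy example, for instance an amine, a carboxylic acid, a methoxy group or a chain longer than ethyl. The compounds shown also leave open how far the result carries to the rest of the shared core, since the butyl chain and the methoxy-bearing aryl ketone are the same in all three.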